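Removing one methoxy from compound 3: an expectation for compound 4

The source may report more compounds than this note shows. Statements on the series, on what has been measured and on what is new or still open speak of the compounds shown alone.

Measured compounds:
compound 1 `c1ccc2c(c1)CC2CCN1CCN(c2cccc3c2OCCCO3)CC1`: 2.68 mg/kg
compound 2 `C1=C(CCN2CCN(c3cccc4c3OCCO4)CC2)c2ccccc2C1`: 0.45 mg/kg
compound 3 `COc1cc2c(cc1OC)C(CCN1CCN(c3cccc4c3OCCO4)CC1)C2`: 1.41 mg/kg

In a functional assay on the whole organism for antagonist activity, with Rattus norvegicus as the target (a higher number here means that more compound is needed for the effect, a lower number that less compound is needed), compound 3 gives 1.41 mg/kg, the second highest of the three numbers. Compound 1 gives 2.68 mg/kg, which lies within the usual scatter of the value of compound 3, so the two cannot be told apart. Compound 2 gives 0.45 mg/kg, a number beyond the scatter below that of compound 3.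

Compound 4 `COc1ccc2c(c1)C(CCN1CCN(c3cccc4c3OCCO4)CC1)C2` differs from compound 3 in one place: hydrogen in place of methoxy on an aromatic carbon. For the measured compounds named here, no pair of measured compounds shows this change alone, so there is no measured step to lean on. With a single heavy-atom pair leaving, a step of modest size is expected, in no clearly favoured direction, and quite possibly none beyond the scatter. The step of a 1.2-fold lower number from compound 3 to compound 4 (0.07 log units; within the scatter) is therefore estimated as small. For compound 4 a value of 1.2 mg/kg is expected, in the range 0.4 mg/kg to 3.5 mg/kg.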

Compound 4, dose for 50% inhibition: 0.48 mg/kg
Compound 4: the middle estimate sits 2.5-fold (0.40 log units) above what was measured; the measured number falls inside the stated range.
By their numbers in this assay, from the lowest: compounds 2 and 4 (each within the scatter of the next); then compounds 3 and 1 (each within the scatter of the next).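

Hydrogen in place of methoxy on this aromatic carbon gives in this assay a 2.9-fold lower number from compound 3 to compound 4 (0.47 log units; beyond the scatter) and so provides the first single-place step in the series. At this position, ortho to a methoxy group, less compound is needed once the methoxy has left, so that group is not required for the effect in compound 3. Nothing given here bears on why the number falls. Still open, going by these compounds, is what hydroxyl, ethoxy or a dimethylamino group would do on this carbon. Also open, on these data alone, is how removing the remaining methoxy would change the number.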